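The source may report more compounds than this note shows. Statements on the series, on what has been measured and on what is new or still open speak of the compounds shown alone.

In a functional assay on MCF7 cells (Homo sapiens) for antiproliferative activity, read by sulforhodamine B assay, with a stated time of 72 h (a lower number here means a stronger inhibitor, a higher number a weaker inhibitor), compound 1 (`COc1ncc(-c2ccc3ncnc(NCc4ccncc4)c3c2)cc1NS(=O)(=O)c1ccc(F)cc1F`) gives 22500 nM, while compound 2 (`COc1ncc(-c2ccc3ncnc(NCCN(C)C)c3c2)cc1NS(=O)(=O)c1ccc(F)cc1F`) gives 1020 nM, the lower of the two numbers. Compound 3 (`COc1ncc(-c2ccc3ncnc(NCCCN(C)C)c3c2)cc1NS(=O)(=O)c1ccc(F)cc1F`) differs from compound 2 in one place: (dimethylamino)methyl in place of dimethylamino on a saturated chain carbon, two bonds along the chain from a nitrogen on an aromatic ring. In words, (dimethylamino)methyl stands in place of dimethylamino on a saturated chain carbon, two bonds along the chain from a nitrogen on an aromatic ring, turning (2-(dimethylamino)ethyl)amino into (3-(dimethylamino)propyl)amino. Going by the values given here, only one measured step bears on this, and it is large: a 22-fold lower number from compound 1 to compound 2 (1.34 log units; beyond the scatter). Among the compounds with values here, that step removes the pyridin-4-yl ring, whereas the new change keeps the dimethylamino end and only lengthens the chain, and no measured pair tests chain length. The expected step is therefore modest, with no clear direction: a 1.1-fold higher number from compound 2 to compound 3 (0.03 log units; within the scatter), which is not expected to exceed the scatter. For compound 3 the estimated value is 1100 nM, within an expected range of 400 nM to 3000 nM.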

Compound 3, half-maximal inhibitory concentration: 3660 nM
The estimate for compound 3 lay 3.3-fold (0.52 log units) below the measured number, and the stated range ends below it.
By their numbers in this assay, from the lowest: compound 2; then compound 3; then compound 1.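

In this assay, chain length at this position proves not to be a silent change: moving from (2-(dimethylamino)ethyl)amino to (3-(dimethylamino)propyl)amino gives a 3.6-fold higher number from compound 2 to compound 3 (0.55 log units; beyond the scatter), which the earlier pair could not show. The longer chain keeps part of the advantage over the pyridin-4-yl group, with a 6.1-fold lower number from compound 1 to compound 3 (0.79 log units; beyond the scatter), so among these three compounds both dimethylamino chains give lower numbers than the ring, and the 2-(dimethylamino)ethyl chain gives the lowest. Nothing available here explains why the two chains differ.

The compounds shown leave open whether a still longer chain, ending in the same dimethylamino group, would raise the number further. They also leave open whether the dimethylamino end itself matters, since a primary amine or a hydroxyl group at the end of either chain would separate the chain's length from its end group.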